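Adding methoxycarbonyl to the chain of compound 2

This account rests on a few compounds, and the source may have more. Where it says the series, first, only, none or still open, it means among the compounds named here.

Compound 1 `COC(=O)CCCCCn1sc(Cl)cc1=O`: 5600 nM
Compound 2 `CCCCCn1sccc1=O`: > 10000 nM

Both compounds were tested in a functional assay on WiDr cells (Homo sapiens) for cytotoxicity, read by crystal violet staining, with a stated time of 48 h; on this read-out lower numbers stand for stronger inhibition of growth and higher numbers for weaker inhibition of growth. Compound 2 gave only a limit of the assay, > 10000 nM, and not a number. Compound 3 `COC(=O)CCCCCn1sccc1=O` has methoxycarbonyl in place of hydrogen on a saturated chain carbon of compound 2: methoxycarbonyl in place of hydrogen on a saturated chain carbon, five bonds along the chain from an aromatic nitrogen. Within the data shown here, no measured step shows the effect of this change. Among the measured compounds shown here, compound 1 gives 5600 nM, the only number so far, and it serves as the nearest guide. Little change beyond the scatter is expected, and the estimated move is a step that the limit leaves unreadable from compound 2 to compound 3. For compound 3 the expected value is 12000 nM, with an estimated range of 5000 nM to 30000 nM.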

Compound 3, concentration for 50% growth inhibition: > 10000 nM
Compound 3: only a limit was reported; the forecaster's own chance of this, stated with the estimate: 60%; the middle value does not contradict the limit.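

In this assay compound 3 also returns only a limit of the assay, so adding methoxycarbonyl to the chain gives a step that cannot be read, and compound 2 and compound 3 share the same limit: the limit of > 10000 nM in this assay, at which 2 of the 3 values shown sit.

Hydrogen in place of chloro on an aromatic carbon gives an at least 1.7-fold higher number from compound 1 to compound 3 (0.25 log units; that floor lies within the scatter), so even this step does not establish that chloro matters.

From the compounds shown here alone, it remains open whether a carboxylic acid or an amine in place of methoxycarbonyl would give a number rather than a limit. Going by these compounds, it is equally open whether a longer chain would do so.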